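The source may report more compounds than this note shows. Statements on the series, on what has been measured and on what is new or still open speak of the compounds shown alone.

Compound 1 `CNc1nc(Cl)nc(NC2(C#N)CCCCC2)n1`: 1070 nM
Compound 2 `CNc1nc(NC2(C#N)CCCCC2)nc(SC)n1`: 46 nM
Compound 3 `CNc1nc(NC2(C#N)CCCCC2)nc(-n2cnc(C#N)n2)n1`: > 5000 nM

These three compounds were measured in an in vitro assay on Sf21 cells for inhibition of high affinity 3',5'-cyclic-AMP phosphodiesterase 7A (Homo sapiens); a higher number here means a weaker inhibitor, a lower number a stronger inhibitor. For compound 3 the value is the limit of this assay, (the limit of > 5000 nM in this assay, at which 1 of the 3 values shown sits), so only a limit and no number is known for it. Compound 4 `CNc1nc(C#N)nc(NC2(C#N)CCCCC2)n1` differs from compound 3 by cyano in place of 3-cyano-1H-1,2,4-triazol-1-yl on an aromatic carbon. For the measured compounds named here, two measured steps bear on this change, since each replaces the cyanotriazolyl with another group on the same aromatic carbon: an at least 100-fold higher number from compound 2 to compound 3 (2.03 log units; beyond the scatter) and an at least 4.6-fold higher number from compound 1 to compound 3 (0.66 log units; beyond the scatter), the chloro of compound 1 and the methylsulfanyl of compound 2 both giving clearly lower numbers than the cyanotriazolyl. Compound 4 is therefore expected to show a lower number, estimated as an at least 8.3-fold lower number from compound 3 to compound 4 (0.92 log units; beyond the scatter). The estimate for compound 4 in this assay is 600 nM, with a range from 120 nM to 3000 nM.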

Compound 4, half-maximal inhibitory concentration: > 1000 nM
Compound 4 gave a limit, no number; the forecaster's own chance of this, stated with the estimate: 15%; middle value at least 1.6-fold (0.22 log units) from the limit.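

In this assay compound 4 gives > 1000 nM, a limit of the assay and not a number. Cyano in place of methylsulfanyl on this aromatic carbon gives an at least 21-fold higher number from compound 2 to compound 4 (1.33 log units; beyond the scatter), so the nitrile alone, without the triazole ring of compound 3, does not reach compound 2 either. Among the groups shown at this carbon, only methylsulfanyl gives a value this low.

The steps from compound 3 to compound 4 and from compound 1 to compound 4 cannot be read. As far as these compounds go, whether a methoxy or an ethylsulfanyl group at this carbon would match methylsulfanyl remains open.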